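The source may report more compounds than this note shows. Statements on the series, on what has been measured and on what is new or still open speak of the compounds shown alone.

Compound 2, whose structure is `COc1ccc(C(=O)/C=C/c2cc(-c3cc(OC)c(OC)c(OC)c3)n[nH]2)cc1OC`, gives the lowest of the two numbers on hand: in a functional assay on MCF7 cells (Homo sapiens) for cytotoxicity, read by sulforhodamine B assay, with a stated time of 48 h, tested at 10 uM (on this read-out lower numbers stand for a stronger effect and higher numbers for a weaker effect at the one concentration tested), compound 2 gives -76%. Within the data shown here, its only measured neighbour is compound 1, `COc1cc(-c2cc(/C=C/C(=O)c3ccc(Cl)c(Cl)c3)[nH]n2)cc(OC)c1OC`, which in this assay gives 15%; the step of a number 91 percentage points lower from compound 1 to compound 2 (beyond the scatter) shows how far apart the two stand. Compound 3, with structure `COc1cc(-c2cc(/C=C/C(=O)c3ccc(F)c(F)c3)[nH]n2)cc(OC)c1OC`, has not yet been measured in this assay. Among the measured compounds shown here, its difference from compound 2 is counted as follows. 3,4-difluorophenyl in place of 3,4-dimethoxyphenyl on a carbonyl carbon The one measured step that bears on this change is the one in which a 3,4-dimethoxyphenyl replaced a 3,4-dichlorophenyl on the same carbonyl carbon, and it moved the read-out a long way downward. Compound 3 reverses the sense of that change, though with fluorine rather than chlorine, so a step back upward is expected for compound 3, of a size near a number 76 percentage points higher from compound 2 to compound 3 (beyond the scatter), because compound 1 gave 15%. The expected value for compound 3 in this assay is therefore 0%, within a range from -50% to 40%.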

Compound 3, a percentage reported as activity, at one concentration (the size of the read-out at that concentration, not a potency): 2%
Compound 3: middle estimate off by 2 percentage points, on the low side; low and high end bracket the measured number.
By their numbers in this assay, from the lowest: compound 2; then compound 3; then compound 1.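

On the carbonyl carbon, the result shows that the low number in this assay goes with the 3,4-dimethoxyphenyl group itself, and not only with the loss of 3,4-dichlorophenyl, since a second replacement of that group gives a number 78 percentage points higher from compound 2 to compound 3 (beyond the scatter) and this step is also large. Exchanging one halogen-bearing ring for the other matters much less, with a number 13 percentage points lower from compound 1 to compound 3 (beyond the scatter) as a modest step, so across these three compounds the main divide lies between the 3,4-dimethoxyphenyl group and the two halogen-bearing groups, while the choice of halogen still leaves a difference beyond the scatter. Nothing on hand gives a reason for this divide.

From the compounds shown here alone, it remains open whether a single methoxy group on that ring would give a number as low as that of compound 2, or whether both are needed. The compounds also leave unanswered what an amine or a carboxylic acid on that ring would do, and whether the same order would hold with a different group on the other side of the shared core.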